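The source may hold more compounds than are shown below. What is called first, only, known or untested is meant among the compounds shown, and "the series" means these compounds.

In a functional assay on HCT-8 cells (Homo sapiens) for antiproliferative activity, read by MTT assay, with a stated time of 48 h (a lower number here means a stronger inhibitor, a higher number a weaker inhibitor), compound 1 `COc1ccc(C(=O)c2ccc3c(c2)C=CC(C)(C)O3)c(NC(=O)CO)c1` gives 250 nM, and compound 2 `CNCC(=O)Nc1cc(OC)ccc1C(=O)c1ccc2c(c1)C=CC(C)(C)O2` gives 1010 nM, the higher of the two numbers. Compound 3 `CCNCC(=O)Nc1cc(OC)ccc1C(=O)c1ccc2c(c1)C=CC(C)(C)O2` differs from compound 2 as follows: methyl in place of hydrogen on a saturated chain carbon bound to an amine nitrogen. This turns methylamino into ethylamino. Among the measured compounds shown here, the only measured step, a 4.0-fold higher number from compound 1 to compound 2 (0.61 log units; beyond the scatter), is a different change, methylamino in place of hydroxy on a saturated chain carbon bound to a carbonyl carbon, so it offers only a loose guide, and no step beyond the scatter is expected in this assay. The estimated step is a 1.1-fold higher number from compound 2 to compound 3 (0.04 log units; within the scatter). For compound 3 the estimated value is 1100 nM, with an expected range of 450 nM to 2700 nM.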

Compound 3, half-maximal inhibitory concentration: 3990 nM
Beside the measured number, compound 3's estimate is 3.6-fold (0.56 log units) below it, outside the stated range (above it).
By their numbers in this assay, from the lowest: compound 1; then compound 2; then compound 3.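

In this assay, one added methyl on a saturated chain carbon bound to an amine nitrogen clearly matters: turning methylamino into ethylamino gives a 4.0-fold higher number from compound 2 to compound 3 (0.60 log units; beyond the scatter), about as large as the earlier step away from hydroxy. Replacing hydroxy with ethylamino gives a 16-fold higher number from compound 1 to compound 3 (1.20 log units; beyond the scatter), so the number climbs with each of the two changes shown. Nothing measured here accounts for these steps. Going by these compounds, whether a longer chain such as propylamino raises the number further remains open, as does how dimethylamino or a plain primary amine would compare with methylamino.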